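A few compounds are considered here, and "the series" means these few. Any claim that something is new, unique, unknown or untested is made for them only; others in the source may bear on it.

In a functional assay on cells (Homo sapiens) for cytotoxicity, read by MTT assay, with a stated time of 24 h (on this read-out higher numbers stand for weaker inhibition and lower numbers for stronger inhibition), compound 3 (`CCCCCCCCCCCCCCNC(=O)[C@H](CO)NCc1ccccc1OC`) gives 100000 nM, the highest of three numbers, against 21700 nM for compound 1 (`CCCCCCCCCCCCCCNC(=O)[C@H](CO)/N=C/c1ccccc1[N+](=O)[O-]`) and 10300 nM for compound 2 (`CCCCCCCCCCCCCCNC(=O)[C@H](CO)/N=C/c1ccccc1Cl`). Compound 4 (`CCCCCCCCCCCCCCNC(=O)[C@H](CO)/N=C/c1ccccc1`) follows from compound 3 through a group of 8 heavy atoms (7 carbon, 1 nitrogen; one six-membered aromatic ring of carbon only) in place of a group of 10 heavy atoms (8 carbon, 1 nitrogen, 1 oxygen; one six-membered aromatic ring of carbon only), on a saturated chain carbon bound to a carbonyl carbon and a saturated chain carbon: (2-methoxybenzyl)amino leaves, and the entering group has 1 double bond outside aromatic rings, as in compound 1 and compound 2. The nearest measured change is a 9.7-fold higher number from compound 2 to compound 3 (0.99 log units; beyond the scatter), modest and beyond the scatter, and compound 4 would reverse most of it. The change of a 2.1-fold lower number from compound 1 to compound 2 (0.32 log units; beyond the scatter) is smaller, so a similar spread is expected around compound 1 and compound 2. A clear drop is expected, estimated as a 6.7-fold lower number from compound 3 to compound 4 (0.82 log units; beyond the scatter). For compound 4 the estimate is 15000 nM, with an expected range of 7000 nM to 35000 nM.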

Compound 4, half-maximal inhibitory concentration: 7670 nM
Estimate against measurement, compound 4: 2.0-fold (0.29 log units) above, within the range that was stated.
By their numbers in this assay, from the lowest: compounds 4 and 2 (each within the scatter of the next); then compound 1; then compound 3.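

In this assay, among these compounds, the change on the saturated chain carbon gives a 13-fold lower number from compound 3 to compound 4 (1.12 log units; beyond the scatter) and is the largest step so far. On the aromatic carbon, hydrogen in place of chloro gives a 1.3-fold lower number from compound 2 to compound 4 (0.13 log units; within the scatter) while hydrogen in place of nitro gives a 2.8-fold lower number from compound 1 to compound 4 (0.45 log units; beyond the scatter) and thus separates only nitro from hydrogen. No evidence on the origin of these steps is available.

The step from compound 3 joins loss of the methoxy with entry of the double bond, leaving their shares unseparated. A plain benzylamino group at this position would separate them.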